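The compounds below may be only part of what the source reports. "The series", "measured", "known", "first", "only" and "open" are said of these compounds alone.

Measured so far:
compound 1, `Cc1ccc(Nc2cnccc2NS(=O)(=O)C(F)(F)F)cc1Br`, gives 44.1% in a functional assay on the whole organism (strain Wistar) with Rattus norvegicus as the target, with stated times of 30 min and 4 h, at a dose of 20 mg/kg by the intraperitoneal route; a lower number here means a weaker effect, a higher number a stronger effect of the compound at the dose given.
compound 2, `O=S(=O)(Nc1ccncc1Nc1ccc(F)c(Cl)c1)C(F)(F)F`, gives 64.7% in this assay.

On these two numbers compound 2 stands highest; its nearest neighbour, compound 1, lies lower by a gap that goes beyond the usual scatter of this measurement. Compound 3, `O=S(=O)(Nc1ccncc1Nc1ccc(F)c(Br)c1)C(F)(F)F`, has not yet been measured. It differs from compound 2 in a single place: bromo in place of chloro on an aromatic carbon. For the measured compounds named here, no pair of measured compounds isolates a change of this kind, so there is no measured guide to how large its effect might be. In this assay such an exchange of one halogen for another is expected to shift the number only a little, if at all beyond the scatter, and in no fixed direction. For compound 3 the estimate is therefore 62%, with a range from 42% to 80%. The expected step of a number 2.7 percentage points lower from compound 2 to compound 3 (within the scatter) is small.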

Compound 3, a percentage reported as activity, at one dose (the size of the read-out at that dose, not a potency): 69.8%
Compound 3: middle estimate off by 7.8 percentage points, on the low side; the measured number falls inside the stated range.
By their numbers in this assay, from the lowest: compound 1; then compounds 2 and 3 (each within the scatter of the next).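

Exchanging one halogen for another on this aromatic carbon, ortho to a fluoro group, makes little measurable difference in this assay, since the result is a number 5.1 percentage points higher from compound 2 to compound 3 (within the scatter) and so chloro and bromo cannot be told apart here. For the compounds shown here, the other exchange behaves differently: with bromo in place on the ring in both compounds, fluoro in place of methyl gives a number 25.7 percentage points higher from compound 1 to compound 3 (beyond the scatter), the first step in this set that clearly exceeds the noise of the measurement. Nothing available explains either step.

It remains open whether this carbon accepts only halogens, as a methoxy group, a nitrile or plain hydrogen there lies outside the compounds shown. As far as these compounds go, whether an ethyl group or a chloro group at the methyl-bearing carbon would behave like methyl or like fluoro also stays open.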